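Hydroxy for Methylsulfanyl at Two Ring Positions

The compounds below may be only part of what the source reports. "The series", "measured", "known", "first", "only" and "open" are said of these compounds alone.

Compound 1 `CSc1cccc(CCCCCC(=O)N2CCOC2=O)c1` gives 12800 nM in an assay on HEK293 cells for inhibition of N-acylethanolamine-hydrolyzing acid amidase (Rattus norvegicus), read by LC-MS, with a stated time of 30 min; a higher number here means a weaker inhibitor, a lower number a stronger inhibitor.
Compound 2 `O=C(CCCCCc1cccc(O)c1)N1CCOC1=O` gives 8640 nM in this assay.
Compound 3 `CSc1ccc(CCCCCC(=O)N2CCOC2=O)cc1` gives only a limit of the assay, > 20000 nM, in this assay.

The change from compound 1 to compound 2 is hydroxy in place of methylsulfanyl on an aromatic carbon. Its measured size is a 1.5-fold lower number from compound 1 to compound 2 (0.17 log units; within the scatter). Compound 3 has the same atoms as compound 1 joined differently; how the two cores differ is not broken down here. Compound 3 sits at the assay limit, (the limit of > 20000 nM in this assay, at which 1 of the 3 values shown sits).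

Compound 4 `O=C(CCCCCc1ccc(O)cc1)N1CCOC1=O` is not yet measured. It differs from compound 3 by hydroxy in place of methylsulfanyl on an aromatic carbon. This is the same kind of change as from compound 1 to compound 2, though the place differs: there the hydroxy is meta to a large group, here it is para to a large group.

The step expected is a step that the limit leaves unreadable from compound 3 to compound 4, resting on the measured step of a 1.5-fold lower number from compound 1 to compound 2 (0.17 log units; within the scatter). Compound 4 is expected to give about 25000 nM, between 10000 nM and 60000 nM, with a fair chance that only a limit is reported again.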

Compound 4, half-maximal inhibitory concentration: 61 nM
Estimate against measurement, compound 4: 410-fold (2.61 log units) above; measured number outside the range, below it.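

The change of hydroxy in place of methylsulfanyl gives an at least 320-fold lower number from compound 3 to compound 4 (2.51 log units; beyond the scatter) in this assay, so on this core, with the hydroxy para to a large group, the same kind of change has a very large effect. A step measured on one core therefore cannot be carried over at the same size to the other core in this series: the same change on two cores in this assay, a 1.5-fold lower number (0.17 log units; within the scatter) from compound 1 to compound 2 and an at least 320-fold lower number (2.51 log units; beyond the scatter) from compound 3 to compound 4, at least 220-fold (2.34 log units) apart, beyond the scatter of two such steps

From the compounds shown here alone, compound 3 gives > 20000 nM, which is a limit of the assay, so the full size of the step stays unknown, and two pairs of compounds do not show why the cores differ or how the change would behave on a further core.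

Going by these compounds, it remains open whether the hydroxy itself is what counts, which a methoxy, an amine or a carboxylic acid at the same place on the ring could help to test. On these data alone, it also remains open whether the result would hold with a longer chain on the shared core.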